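Methoxy for Chloro on the Benzyl Arm of Compound 1

The source may hold more compounds than are shown below. What is called first, only, known or untested is meant among the compounds shown, and "the series" means these compounds.

In a functional assay on MDA-MB-435 cells (Homo sapiens) for cytotoxicity, read by MTT assay, with a stated time of 72 h (on this read-out higher numbers stand for weaker inhibition and lower numbers for stronger inhibition), two compounds have been measured so far. Compound 1 `N[C@H]1CC[C@H](Nc2c(C(=O)NCc3ccc(Cl)cc3)nc(Br)c3cccnc23)CC1` gives 1000 nM in this assay, the lower of the two numbers. Compound 2 `Nc1ccc(Nc2c(C(=O)NCc3ccc(F)cc3)nc(Br)c3cccnc23)cc1` gives 7000 nM in this assay, a number that lies well beyond the usual scatter from that of compound 1. The two differ in more than one place, so their values are set side by side without tracing the gap to a single change. Compound 3 `COc1ccc(CNC(=O)c2nc(Br)c3cccnc3c2N[C@H]2CC[C@H](N)CC2)cc1` has not yet been measured. It differs from compound 1 in one spot: methoxy in place of chloro on an aromatic carbon. The exchange sits on an aromatic carbon of a six-membered aromatic ring of carbon only, para to a large group; cut one bond further out it reads 4-chlorobenzyl to 4-methoxybenzyl. Among the measured compounds shown here, no step between measured compounds covers this change, so the only anchor is compound 1 and its 1000 nM in this assay. The expected step is a 1.5-fold higher number from compound 1 to compound 3 (0.18 log units; within the scatter), small and most likely within the scatter, if anything leaning toward weaker inhibition. Compound 3 is therefore estimated at 1500 nM, with a range from 500 nM to 5000 nM.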

Compound 3, half-maximal inhibitory concentration: 5000 nM
Estimate against measurement, compound 3: 3.3-fold (0.52 log units) below; the range from low to high includes it.
By their numbers in this assay, from the lowest: compound 1; then compounds 3 and 2 (each within the scatter of the next).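

In this assay the aromatic carbon para to a large group on the benzyl arm proves sensitive to what it carries: methoxy in place of chloro brings a 5.0-fold higher number from compound 1 to compound 3 (0.70 log units; beyond the scatter) and so moves the read-out beyond the scatter, toward weaker inhibition. This is the only step shown that follows a single change, whereas the earlier pair differed in more than one place and could not tie any gap to this position. Nothing shown explains why the exchange of chloro for methoxy has this size.

With only one step at this position, the compounds shown cannot say whether chloro is a favourable group here or methoxy an unfavourable one, and how a plain hydrogen, a methyl, a hydroxyl or a trifluoromethyl on the same carbon would compare with compound 1 remains open. Going by these compounds, it also remains open whether the same exchange would give a step of similar size on a compound with a different amine arm, since this step has been read only with the arm that compound 1 and compound 3 share.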